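Chloro for trifluoromethyl: clearance notes on compound 4

The source may report more compounds than this note shows. Statements on the series, on what has been measured and on what is new or still open speak of the compounds shown alone.

Measured in an in vitro ADME assay on microsomes from liver (Homo sapiens) for metabolic stability, using NADPH; on this read-out higher numbers stand for fast clearance and lower numbers for slow clearance:
- compound 1 `COc1ccc(Cl)cc1Cn1c(C(=O)NCC(C)(C)CO)cc2cc(C#N)ccc21`: 83 mL.min-1.g-1
- compound 2 `COc1ccc(Br)cc1Cn1c(C(=O)NCC(C)(C)CO)cc2cc(C#N)ccc21`: 104 mL.min-1.g-1
- compound 3 `Cc1ccc(C(F)(F)F)cc1Cn1c(C(=O)NCC(C)(C)CO)cc2cc(C#N)ccc21`: 180 mL.min-1.g-1

Compound 3 lies within the scatter of compound 2 and stands beyond the scatter above compound 1, so it sits at the fast-clearance end of this small set. The next compound is compound 4 `Cc1ccc(Cl)cc1Cn1c(C(=O)NCC(C)(C)CO)cc2cc(C#N)ccc21`, with the change (chloro in place of trifluoromethyl on an aromatic carbon), chloro in place of trifluoromethyl on an aromatic carbon, para to a methyl group.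

Within the data shown here, no measured step covers this exchange. The nearest is the halogen exchange a 1.3-fold higher number from compound 1 to compound 2 (0.10 log units; within the scatter), which stays within the scatter but does not involve trifluoromethyl. Compound 1 also carries chloro and gives 83 mL.min-1.g-1, although it differs from compound 4 in a second place. This supports only a modest expectation of a lower number in this assay. The expected change is a 1.4-fold lower number from compound 3 to compound 4 (0.14 log units; within the scatter), which would not clearly exceed the scatter. For compound 4 the estimated value is 130 mL.min-1.g-1, with an expected range of 75 mL.min-1.g-1 to 210 mL.min-1.g-1.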

Compound 4, intrinsic clearance in microsomes: 119 mL.min-1.g-1
Estimate against measurement, compound 4: 1.1-fold (0.04 log units) above, within the range that was stated.
By their numbers in this assay, from the lowest: compounds 1, 2, 4 and 3 (each within the scatter of the next, the first and the last beyond it).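

Working notes on the series: in this assay, chloro in place of trifluoromethyl, para to a methyl group, gives a 1.5-fold lower number from compound 3 to compound 4 (0.18 log units; within the scatter) and so provides the first direct reading of this exchange at this position. With chloro held, methyl in place of methoxy gives a 1.4-fold higher number from compound 1 to compound 4 (0.16 log units; within the scatter) and the exchange of the whole aryl group gives a 1.1-fold higher number from compound 2 to compound 4 (0.06 log units; within the scatter), which leaves compound 4 within the scatter of all three earlier compounds, although compound 1 and compound 3 lie beyond the scatter of each other. No measurement is available that accounts for these steps.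

From the compounds shown here alone, it remains open whether either single change can move clearance beyond the scatter on its own. An amine or a carboxylic acid in place of the chloro of compound 4 would test how far this position can shift the read-out.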